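Swapping Chloro for Trifluoromethyl on a Desaturase Inhibitor

The compounds below may be only part of what the source reports. "The series", "measured", "known", "first", "only" and "open" are said of these compounds alone.

Compound 1, `Clc1cccc(Nc2cccc3ccccc23)c1`: in an assay for inhibition of acyl-CoA (8-3)-desaturase (Homo sapiens) (on this read-out higher numbers stand for weaker inhibition and lower numbers for stronger inhibition), compound 1 gives 17 nM.
Compound 2, `Fc1cccc(Nc2n[nH]c3ccccc23)c1`: in this assay compound 2 gives 59 nM.
Compound 3, `Clc1cccc(Nc2n[nH]c3ccc(Cl)cc23)c1`: in this assay compound 3 gives 5 nM.

Compound 3 has the lowest number of the three, and its gaps to compound 1 and to compound 2 both lie beyond the scatter, so it is the strongest inhibitor among them. Compound 4, `FC(F)(F)c1ccc2[nH]nc(Nc3cccc(Cl)c3)c2c1`, differs from compound 3 in one place: trifluoromethyl in place of chloro on an aromatic carbon, meta to a fused ring and para to a fused ring. Among the measured compounds shown here, no measured pair shows what this swap does, so the expected step in this assay is small, with no clear direction, and probably within the scatter. Compound 4 is therefore expected to give 6 nM, within 2 nM to 20 nM, which means an estimated step of a 1.2-fold higher number from compound 3 to compound 4 (0.08 log units; within the scatter).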

Compound 4, half-maximal inhibitory concentration: 254 nM
Compound 4: middle estimate off by 42-fold (1.63 log units), on the low side; measured number above the stated range.
By their numbers in this assay, from the lowest: compound 3; then compound 1; then compound 2; then compound 4.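

This position on the shared core is far from indifferent: in this assay, trifluoromethyl in place of chloro brings a 51-fold higher number from compound 3 to compound 4 (1.71 log units; beyond the scatter) and clearly weakens inhibition. The earlier compounds shown here differ from one another in more than one place, so they could not reveal what a single change here does.

From the compounds shown here alone, whether methyl, bromo or a nitrile on this carbon would keep the inhibition seen with compound 3 remains open. Why this one swap matters so much also stays open, as no measurement here bears on it.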